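Extending the Acyl Chain of Compound 3

The source may report more compounds than this note shows. Statements on the series, on what has been measured and on what is new or still open speak of the compounds shown alone.

Of the compounds shown here, three have so far been measured in a functional assay on PC-3 cells (Homo sapiens) for cytotoxicity, read by sulforhodamine B assay, with a stated time of 72 h; a higher number here means a weaker inhibitor of growth, a lower number a stronger inhibitor of growth. Compound 1 `O=C(Nc1ccccc1O)C1CCc2ccccc2N1C(=O)c1ccccc1Cl` gives 60000 nM in this assay. For the measured compounds named here, compound 2 `O=C(Nc1ccccc1O)C1CCc2ccccc2N1C(=O)c1ccc(Cl)cc1`, with 4-chlorophenyl in place of 2-chlorophenyl on a carbonyl carbon, gives 25100 nM, and the step of a 2.4-fold lower number from compound 1 to compound 2 (0.38 log units; beyond the scatter) is the only measured step among the three. Compound 3 `CCCC(=O)N1c2ccccc2CCC1C(=O)Nc1ccccc1C(F)(F)F` is recorded only as a limit of this assay, > 70000 nM. That limit, (the limit of > 70000 nM in this assay, at which 1 of the 3 values shown sits), is the single point of reference for compound 3, so its place relative to the other two is not fixed by a number.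

Compound 4 `CCCCCCCCC(=O)N1c2ccccc2CCC1C(=O)Nc1ccccc1C(F)(F)F` differs from compound 3 by pentyl in place of hydrogen on a saturated chain carbon, three bonds along the chain from a carbonyl carbon. Going by the values given here, the one measured step concerns the chlorophenyl ring of compounds 1 and 2 and does not touch the acyl chain, so no measured step bears on this change, and no evidence on the chain itself exists. The step from compound 3 to compound 4 is therefore expected to be small, a number no higher from compound 3 to compound 4 (the limit leaves the size open), with no direction established beyond the scatter. Compound 4 is estimated at 70000 nM, with a range from 20000 nM to 200000 nM, and it may again be reported only as a limit.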

Compound 4, concentration for 50% growth inhibition: 4320 nM
Compound 4: the middle estimate sits 16-fold (1.21 log units) above what was measured; the measured number lies below the stated range.
By their numbers in this assay, from the lowest: compound 4; then compound 2; then compound 1. At a limit, above all of these: compound 3.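

Extending the acyl chain is the first change among the compounds shown to produce a large shift in this assay: an at least 16-fold lower number from compound 3 to compound 4 (1.20 log units; beyond the scatter). For the compounds shown here, the only earlier step concerned the chlorophenyl ring and was modest, so this result shows for the first time that the acyl chain, at this place on a saturated chain carbon, three bonds along the chain from a carbonyl carbon, strongly affects the growth-inhibition reading. Compound 3 is recorded only as a limit, so the step has a lower bound but no upper one: the limit of > 70000 nM in this assay, at which 1 of the 4 values shown sits.

As far as these compounds go, with only these two chain lengths in hand, it remains open whether the number falls steadily as the chain grows, reaches a plateau or turns back, as a chain of intermediate length or a longer chain would show. Going by these compounds alone, it is also open whether a terminal amine or carboxylic acid on the chain would keep this gain, and whether the same chain would have a similar effect with the amide carried by compound 1 and compound 2 in place of the one in compound 4.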